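Swapping an Amino Side Chain for Butoxy: a Cytotoxicity Outlook

The source may report more compounds than this note shows. Statements on the series, on what has been measured and on what is new or still open speak of the compounds shown alone.

Compound 1 `CC(C)Nc1nc(N)nc2c1ncn2/C=C1/CC1(CO)CO` gives > 24000 nM in an ADME assay on Akata cells (Homo sapiens) for cytotoxicity, with a stated time of 7 days; on this read-out lower numbers stand for higher toxicity in this test and higher numbers for lower toxicity in this test.
Compound 2 `CCCNc1nc(N)nc2c1ncn2/C=C1/CC1(CO)CO` gives > 24000 nM in this assay.
Compound 3 `CCCOc1nc(N)nc2c1ncn2/C=C1/CC1(CO)CO` gives > 20000 nM in this assay.

Three compounds share one core and differ only in the group on one aromatic carbon. For compound 1 the value is not a number but a limit of the measurement. The same holds for compound 2, whose value is a limit. For compound 3 the value is likewise a limit. Since the limit of > 24000 nM in this assay, at which 2 of the 3 values shown sit, and the limit of > 20000 nM in this assay, at which 1 of the 3 values shown sits, are ceilings of what this test can report, the steps a step that the two limits leave unreadable from compound 1 to compound 2, a step that the two limits leave unreadable from compound 1 to compound 3 and a step that the two limits leave unreadable from compound 2 to compound 3 cannot be sized; none is readable in either direction.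

Compound 4 `CCCCOc1nc(N)nc2c1ncn2/C=C1/CC1(CO)CO` is not yet measured. Relative to compound 1 the change is butoxy in place of isopropylamino on an aromatic carbon. Among the measured compounds shown here, no measured step gives a readable size, so no step beyond the scatter is expected, and compound 4 is expected to reach the ceiling again. Compound 4 is therefore estimated at 30000 nM. For compound 4 the expected range runs from 15000 nM to 60000 nM. The step this estimate means is a step that the limit leaves unreadable from compound 1 to compound 4.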

Compound 4, half-maximal cytotoxic concentration: > 20000 nM
Compound 4: no number, only a limit (the forecaster's own chance of this, stated with the estimate: 80%); the middle value is on the limit's open side.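

Compound 4 gives > 20000 nM in this assay as a limit, not a number, so its steps from compound 1, compound 2 and compound 3 cannot be read. The compounds shown leave open what concentration harms these cells, and whether butoxy, propoxy, propylamino and isopropylamino differ at all.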